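The source may report more compounds than this note shows. Statements on the series, on what has been measured and on what is new or still open speak of the compounds shown alone.

Measured so far in a functional assay on HCT-15 cells (Homo sapiens) for antiproliferative activity, read by sulforhodamine B assay; a lower number here means a stronger inhibitor of growth, a higher number a weaker inhibitor of growth:
- compound 1, `CC(C)=CCOc1cccc(O)c1C(=O)/C=C/c1ccc(O)cc1`: compound 1 gives > 30000 nM, a limit of the assay rather than a number.
- compound 2, `CC(C)(C)CCOc1cccc(O)c1C(=O)/C=C/c1ccc(C(=O)O)cc1`: compound 2 gives 2170 nM.
- compound 3, `O=C(/C=C/c1ccc(O)cc1)c1c(O)cccc1OCC1CCCC1`: compound 3 gives 3410 nM.

Compound 3 gives the higher of the two numbers; the nearest is compound 2, whose number is lower by a margin within the scatter, so no order between the two is claimed. The third value is one that sits at the limit of > 30000 nM in this assay, at which 1 of the 3 values shown sits. Going by the values given here, the single one-place step measured, an at least 8.7-fold lower number from compound 1 to compound 3 (0.94 log units; beyond the scatter), is at least modest and runs toward a lower number.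

Compound 4, `CC(C)(C)CCOc1cccc(O)c1C(=O)/C=C/c1ccc(O)cc1`, has not yet been measured in this assay. It differs from compound 3 in one place: neopentyl in place of cyclopentyl on a saturated chain carbon bound to an oxygen on an aromatic ring. Among the compounds with values here, no measured step swaps one of these two groups for the other. The step of an at least 8.7-fold lower number from compound 1 to compound 3 (0.94 log units; beyond the scatter) bears on it only in showing that the group on this oxygen can shift the number by a sizeable margin, but that step carried 2-methylprop-1-en-1-yl out and cyclopentyl in, so it sets no direction here. Compound 2 carries the same 3,3-dimethylbutoxy chain that enters compound 4 but bears a carboxylic acid where compound 4 bears a hydroxyl; its number and that of compound 3 sit within the scatter of each other, the only pointer available. The step of a 1.1-fold lower number from compound 3 to compound 4 (0.06 log units; within the scatter) is therefore expected to stay within the scatter, in no firm direction. Compound 4 is estimated at 3000 nM, with a range from 1200 nM to 8000 nM.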

Compound 4, concentration for 50% growth inhibition: 3430 nM
For compound 4 the middle estimate is 1.1-fold (0.06 log units) below the measured one, within the range that was stated.
By their numbers in this assay, from the lowest: compounds 2, 3 and 4 (each within the scatter of the next). At a limit, above all of these: compound 1.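

In this assay, a 1.0-fold higher number from compound 3 to compound 4 (0.00 log units; within the scatter) shows that this oxygen substituent tolerates the swap of cyclopentyl for neopentyl, a ring for no ring at the same count of 5 heavy atoms, with no shift beyond the scatter. Going by these compounds alone, with the 3,3-dimethylbutoxy chain held fixed, a 1.6-fold higher number from compound 2 to compound 4 (0.20 log units; within the scatter) gives the first direct reading of the other end of the molecule, and hydroxy in place of carboxy on an aromatic carbon leaves the number within the scatter. The step of an at least 8.7-fold lower number from compound 1 to compound 4 (0.94 log units; beyond the scatter) shows that a second saturated group, not cyclopentyl alone, separates from 2-methylprop-1-en-1-yl, although this step starts from a limit and not a number: the limit of > 30000 nM in this assay, at which 1 of the 4 values shown sits.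

The compounds shown leave open whether any group on this oxygen moves the number clearly away from those of the saturated groups, for example a longer chain, a benzyl group or a chain ending in an amine. They also leave open whether the hydroxy and carboxy groups stay level with a chain other than 3,3-dimethylbutoxy, such as cyclopentylmethoxy, and how an amine at that aromatic carbon would read.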